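The source may hold more compounds than are shown below. What is called first, only, known or untested is meant among the compounds shown, and "the series" means these compounds.

Values in a functional assay on P388 cells (Mus musculus) for antiproliferative activity, read by colorimetric assay and MTT assay (on this read-out higher numbers stand for weaker inhibition and lower numbers for stronger inhibition), for the measured compounds:

compound 1, `N#Cc1ccc(S(=O)(=O)Nc2ccc(Cl)c3cc[nH]c23)cc1`: 1.8 ug/mL
compound 2, `N#Cc1ccc(S(=O)(=O)Nc2ccc(Cl)c3c(Cl)c[nH]c23)cc1`: 0.59 ug/mL
compound 3, `Nc1ccc(S(=O)(=O)Nc2cccc3cc[nH]c23)cc1`: 14 ug/mL

Compound 1 and compound 2 share one core and differ in a single place: chloro in place of hydrogen on an aromatic carbon. That change gives a 3.1-fold lower number from compound 1 to compound 2 (0.48 log units; beyond the scatter).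

Compound 3 stands on a different core; how that core differs from the core of compound 1 is not broken down here. In this assay compound 3 gives the highest of the three numbers, and both gaps, to compound 1 and to compound 2, lie beyond the scatter.

Compound 4, `Nc1ccc(S(=O)(=O)Nc2cccc3cc(Cl)[nH]c23)cc1`, has not been measured. It differs from compound 3 in one place: chloro in place of hydrogen on an aromatic carbon. This is the same kind of change as from compound 1 to compound 2, but not the same: there the chloro enters on a carbon two ring bonds from the ring nitrogen, here on a carbon next to the ring nitrogen. Among the measured compounds shown here, the only guide to the size of the step is a 3.1-fold lower number from compound 1 to compound 2 (0.48 log units; beyond the scatter), made on a different core and at a different place, so the carry-over is uncertain.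

For compound 4 a step down in this assay of a 2.2-fold lower number from compound 3 to compound 4 (0.33 log units; beyond the scatter) is expected, somewhat smaller than the measured one because a 3.1-fold lower number from compound 1 to compound 2 (0.48 log units; beyond the scatter) was seen at another place on another core. Compound 4 is therefore estimated at 6.5 ug/mL, with a likely range from 2.5 ug/mL to 16 ug/mL.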

Compound 4, half-maximal inhibitory concentration: 2.2 ug/mL
Compound 4: the middle estimate sits 3.0-fold (0.47 log units) above what was measured; measured number outside the range, below it.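

In this assay, chloro in place of hydrogen on an aromatic carbon of the five-membered aromatic ring, next to the ring nitrogen, gives a 6.4-fold lower number from compound 3 to compound 4 (0.80 log units; beyond the scatter), so the number falls on this core as well. Set beside the earlier step, the two changes point the same way and their sizes cannot be told apart: the same change on two cores in this assay, a 3.1-fold lower number (0.48 log units; beyond the scatter) from compound 1 to compound 2 and a 6.4-fold lower number (0.80 log units; beyond the scatter) from compound 3 to compound 4, 2.1-fold (0.32 log units) apart, within the scatter of two such steps This supports carrying the direction of the chloro step from one core to another in this series, and a size of the same order, but it rests on only two pairs; since the chloro enters at a different place in each pair, the effect of the core cannot be separated from the effect of the place, and nothing here shows that the step would hold on further cores.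

Still open, from the compounds shown here alone, is whether the same chloro step appears when each core carries the chloro at the place used on the other, which would separate core from place. Also open, going by these compounds, is whether a bromo, methyl or methoxy group on the same carbon would lower the number as chloro does, or whether the step is particular to chloro.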